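The source may report more compounds than this note shows. Statements on the series, on what has been measured and on what is new or still open speak of the compounds shown alone.

Compound 1, `CC(C)C[C@H](N)c1cc(Cl)ccc1N1CCN(C(=O)C2NCCC2c2ccc(Cl)cc2)CC1`: 96 nM
Compound 2, `COc1ccc([C@H]2CCN(C(C)=O)[C@H]2C(=O)N2CCN(c3ccc(C)cc3[C@@H](N)C(C)C)CC2)cc1`: 45 nM
Compound 3, `Cc1ccc(N2CCN(C(=O)[C@H]3[C@@H](c4ccc(Cl)cc4)CCN3C(C)C)CC2)c([C@@H](N)C(C)C)c1`: 110 nM

All three compounds share a core and differ in the groups carried on the five-membered ring. In an assay on HEK293 cells for displacement of a labelled ligand from Melanocortin receptor 4 (Homo sapiens) (a lower number here means a stronger inhibitor, a higher number a weaker inhibitor), compound 3 gives 110 nM, the highest of the three numbers. Compound 1 gives 96 nM, which lies within the usual scatter of compound 3, so the two cannot be told apart. Compound 2 gives 45 nM, a lower number that falls beyond the scatter, so compound 2 is the tighter binder of that pair.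

Compound 4, `Cc1ccc(N2CCN(C(=O)[C@H]3[C@@H](c4ccc(Cl)cc4)CCN3C)CC2)c([C@@H](N)C(C)C)c1`, is not yet measured. It differs from compound 3 in one place: methyl in place of isopropyl on an amine nitrogen in a ring. Going by the values given here, no measured pair isolates this change, so its effect has to be guessed from the compounds above, all of which bind in a similar range. A modest step is expected, with the direction uncertain and most likely no change beyond the scatter. The step from compound 3 to compound 4 is expected to be a 1.2-fold lower number from compound 3 to compound 4 (0.09 log units; within the scatter). Compound 4 is expected to give about 90 nM in this assay, with a likely range from 35 nM to 230 nM.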

Compound 4, inhibition constant: 160 nM
Compound 4: middle estimate off by 1.8-fold (0.25 log units), on the low side; measured number inside the range.
By their numbers in this assay, from the lowest: compound 2; then compounds 1, 3 and 4 (each within the scatter of the next).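

Going by these compounds alone, compound 3 and compound 4 form the first pair that isolates the group on the amine nitrogen in the five-membered ring. In this assay, methyl in place of isopropyl gives a 1.5-fold higher number from compound 3 to compound 4 (0.16 log units; within the scatter), so this pair cannot be told apart even though the group shrinks from 3 heavy atoms to 1. At this position, and with the rest of compound 3 kept the same, binding therefore does not clearly depend on which of these two small groups is present. No measurement here bears on why the step is this size.

On these data alone, it remains open whether a larger group on this nitrogen, such as benzyl or a longer chain like n-butyl, would also leave binding unchanged. A chain ending in a carboxylic acid is equally untested here, and this single pair cannot show whether the same holds when other parts of the molecule differ.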